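Moving the Methyl Round the Sulfonamide Ring

The compounds below may be only part of what the source reports. "The series", "measured", "known", "first", "only" and "open" are said of these compounds alone.

Compound 1 `O=S(=O)(Nc1ccc(-c2nc3ccccc3o2)cc1)c1ccccc1C(F)(F)F` and compound 2 `Cc1ccccc1S(=O)(=O)Nc1ccc(-c2nc3ccccc3o2)cc1` share a core and differ only in the group on one aromatic carbon. In an assay on isolated protein for inhibition of malate dehydrogenase, mitochondrial (Sus scrofa), with stated times of 45 min and 30 min (on this read-out higher numbers stand for weaker inhibition and lower numbers for stronger inhibition), compound 1 gives > 63000 nM, which is a limit of the assay and not a number. In this assay compound 2 gives > 63000 nM, again a limit rather than a measured number. The step that the two limits leave unreadable from compound 1 to compound 2 is therefore unreadable because both values sit at the limit of > 63000 nM in this assay, at which 2 of the 2 values shown sit. Within the data shown here, compound 2 thus stands at the limit, and the one further value shown is a limit as well.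

Compound 3 `Cc1ccc(S(=O)(=O)Nc2ccc(-c3nc4ccccc4o3)cc2)cc1` differs from compound 2 by 4-methylphenyl in place of 2-methylphenyl on a sulfonyl sulfur. Among the measured compounds shown here, no measured step bears on this change, so no size or direction beyond the scatter can be expected from the data. The step that the limit leaves unreadable from compound 2 to compound 3 is estimated to stay within the scatter. In this assay compound 3 is expected to give 100000 nM, with a range from 40000 nM to 300000 nM, most likely again as a limit.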

Compound 3, half-maximal inhibitory concentration: > 63000 nM
Compound 3: no number, only a limit; the forecaster's own chance of this, stated with the estimate: 85%; the middle value lies beyond the limit too.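

In this assay compound 3 also gives only a limit, so no step between compound 2 and compound 3 can be read: the limit of > 63000 nM in this assay, at which 3 of the 3 values shown sit.

The compounds shown leave open whether 2-methylphenyl and 4-methylphenyl differ at all, and which change would give a measured number in this assay.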